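Removing the nitro group from compound 2

The source may report more compounds than this note shows. Statements on the series, on what has been measured and on what is new or still open speak of the compounds shown alone.

Compound 1 `CCn1ccnc1-c1cc(OC)c(OC)c(OC)c1` – > 100000 nM (a limit of the assay)
Compound 2 `COc1ccc(-n2ccnc2-c2cc(OC)c(OC)c(OC)c2)cc1[N+](=O)[O-]` – 7500 nM

Among the compounds with values here, in a functional assay on MDA-MB-231 cells (Homo sapiens) for antiproliferative activity, read by MTT assay, with a stated time of 72 h (on this read-out higher numbers stand for weaker inhibition and lower numbers for stronger inhibition), compound 2 gives 7500 nM and holds the only true number so far. The single other result is a limit and not a number: compound 1 reads > 100000 nM in this assay and can serve only as a limit.

Compound 3 `COc1ccc(-n2ccnc2-c2cc(OC)c(OC)c(OC)c2)cc1` has not yet been measured. It departs from compound 2 in one place, with hydrogen in place of nitro on an aromatic carbon, ortho to a methoxy group (hydrogen in place of nitro on an aromatic carbon).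

Within the data shown here, no measured pair isolates this change, so the series offers no direct guide to its size or direction. Among the measured compounds shown here, the only numerical anchor is compound 2 at 7500 nM and the expectation therefore stays close to it. The expected change is a 1.5-fold lower number from compound 2 to compound 3 (0.18 log units; within the scatter) and no shift beyond the usual scatter is expected, although the uncertainty is wide in both directions. In this assay compound 3 is expected at 5000 nM (estimated range 800 nM to 40000 nM).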

Compound 3, half-maximal inhibitory concentration: 2700 nM
Compound 3: middle estimate off by 1.9-fold (0.27 log units), on the high side; low and high end bracket the measured number.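

In this assay, the step at this position, hydrogen in place of nitro on an aromatic carbon, ortho to a methoxy group, gives a 2.8-fold lower number from compound 2 to compound 3 (0.44 log units; beyond the scatter). Compound 3 therefore shows that the nitro group is not required for activity on this scaffold, and that its loss goes with stronger inhibition, a change that lies beyond the usual scatter. With the nitro group gone, the aromatic nitrogen can also be read as a single change, since 4-methoxyphenyl in place of ethyl gives an at least 37-fold lower number from compound 1 to compound 3 (1.56 log units; beyond the scatter), a larger step than the one at the nitro position, though its size is only a bound, as compound 1 stands at a limit of the assay and not at a number: the limit of > 100000 nM in this assay, at which 1 of the 3 values shown sits.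

What an amine, a hydroxyl group or a chlorine atom at the nitro position would do remains open, as does any cause for the step from nitro to hydrogen. As far as these compounds go, on the aromatic nitrogen, it also remains open how a longer chain such as butyl, or a phenyl ring without its methoxy group, would read.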